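Oxime series on the shared core: O-methylation of the hydroxy group

This account rests on a few compounds, and the source may have more. Where it says the series, first, only, none or still open, it means among the compounds named here.

Measured so far:
compound 1 `Cc1cccc(/C(=N\O)C(O)CN2CCN(c3ccccn3)CC2)c1` — 44.8 nM
compound 2 `Cc1cccc(/C(=N/O)C(O)CN2CCN(c3ccccn3)CC2)c1` — 4.9 nM

Among the measured compounds shown here, in a functional assay on HEK293 cells with D(4) dopamine receptor (Homo sapiens) as the target, read by FLIPR (on this read-out lower numbers stand for an effect already at smaller amounts and higher numbers for an effect only at larger amounts of compound), compound 1 gives 44.8 nM, the higher of the two numbers; the only neighbour is a 9.1-fold lower number from compound 1 to compound 2 (0.96 log units; beyond the scatter), a change in the drawn configuration of the oxime (the fact that one of compounds 1 and 2 is drawn with a defined configuration and the other without, at the place where they differ). Compound 3 `COC(CN1CCN(c2ccccn2)CC1)/C(=N/O)c1cccc(C)c1` carries methyl in place of hydrogen on an oxygen on a saturated carbon. For the measured compounds named here, no measured step covers a hydroxy-to-methoxy change, and the step from compound 1 to compound 2 concerns a different place, so it does not bear on it. Compound 3 is therefore expected near compound 1, with a wide range: 60 nM (15 nM to 300 nM). The expected step is a 1.3-fold higher number from compound 1 to compound 3 (0.13 log units; within the scatter).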

Compound 3, half-maximal effective concentration: 5370 nM
Estimate against measurement, compound 3: 90-fold (1.95 log units) below; the measured number lies above the stated range.
By their numbers in this assay, from the lowest: compound 2; then compound 1; then compound 3.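

In this assay the hydroxy-to-methoxy change gives a 120-fold higher number from compound 1 to compound 3 (2.08 log units; beyond the scatter), so a single added methyl on this oxygen is enough to move the number far, which compounds 1 and 2, both carrying the free hydroxy group, could not show. Nothing in the data at hand accounts for this step.

Open, as far as these compounds go, is whether the rise belongs to the methyl alone or to any group on this oxygen, such as ethyl or acetyl, and how an amine or a fluorine in place of the hydroxy group would read. Also open, from the compounds shown here alone, is whether the same change has a step of similar size on the oxime configuration of compound 2.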